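Methylating the Amide Nitrogen of Compound 1

This account rests on a few compounds, and the source may have more. Where it says the series, first, only, none or still open, it means among the compounds named here.

compound 1 `Cc1cc(Cl)ccc1C(=O)Nc1cccnc1`: 277 nM
compound 2 `O=C(Nc1cccnc1)c1ccc(Cl)cc1`: 420 nM
compound 3 `CN(C(=O)c1ccc(C#N)cc1)c1cccnc1`: only a limit, > 3000 nM

In an assay on cells for inhibition of cytochrome P450 11B2, mitochondrial (Homo sapiens), read by HTRF (a higher number here means a weaker inhibitor, a lower number a stronger inhibitor), compound 1 gives 277 nM, the lowest of the two numbers shown. Compound 2 stands nearest, and the step of a 1.5-fold higher number from compound 1 to compound 2 (0.18 log units; within the scatter) lies within the scatter. Compound 3 reaches only (the limit of > 3000 nM in this assay, at which 1 of the 3 values shown sits).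

Compound 4 `Cc1cc(Cl)ccc1C(=O)N(C)c1cccnc1` differs from compound 1 by methyl in place of hydrogen on an amide-type nitrogen. Going by the values given here, no measured step carries this same change, so none bears on it directly. Among the compounds shown, only compound 3 carries a methyl on its amide-type nitrogen, and compound 3 gives only a limit in this assay. On that thin footing a step toward a higher number is expected, a 5.4-fold higher number from compound 1 to compound 4 (0.73 log units; beyond the scatter). Compound 4 is estimated at 1500 nM, with a range from 400 nM to 6000 nM.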

Compound 4, half-maximal inhibitory concentration: > 3000 nM
Compound 4 ended at the assay's limit; the forecaster's own chance of this, stated with the estimate: 30%; middle value at least 2.0-fold (0.30 log units) from the limit.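

Going by these compounds alone, putting methyl in place of the amide hydrogen gives the first direct reading at this position, and the change is large: an at least 10-fold higher number from compound 1 to compound 4 (1.03 log units; beyond the scatter) in this assay. Going by these compounds, the result for compound 4 is a limit and not a number, so the true size of the step remains unknown. The only two compounds shown with a methyl on the amide-type nitrogen, compound 3 and compound 4, both sit at that limit: the limit of > 3000 nM in this assay, at which 2 of the 4 values shown sit.

On these data alone, it remains open whether an ethyl or a longer chain on this nitrogen would behave like methyl. As far as these compounds go, whether methyl has the same effect on compound 2 also remains open.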